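Swapping a Chlorophenyl for a Fluorophenyl on Two Cores

The source may report more compounds than this note shows. Statements on the series, on what has been measured and on what is new or still open speak of the compounds shown alone.

Compound 1 `O=C(NNc1cccc(Cl)c1)c1ccc(NS(=O)(=O)c2cnc(O)nc2O)cc1` carries a 3-chlorophenyl group on an amine nitrogen, and in a functional assay on OVCAR-3 cells (Homo sapiens) for antiproliferative activity, read by MTT assay, with a stated time of 24 h (on this read-out higher numbers stand for weaker inhibition and lower numbers for stronger inhibition), compound 1 gives 8410 nM. Compound 2 `O=C(NNc1ccccc1F)c1ccc(NS(=O)(=O)c2cnc(O)nc2O)cc1` differs from it by 2-fluorophenyl in place of 3-chlorophenyl on an amine nitrogen. For compound 2 this assay reports only a limit, > 20000 nM. That makes the step of an at least 2.3-fold higher number from compound 1 to compound 2 (0.37 log units; beyond the scatter), which rests on (the limit of > 20000 nM in this assay, at which 1 of the 3 values shown sits). Compound 3 `O=C(NNc1cccc(Cl)c1)c1ccccc1NS(=O)(=O)c1cnc(O)nc1O` is built from the same atoms as compound 1, joined differently; the difference between the two cores is not broken down here. In this assay compound 3 gives 5520 nM. Compound 4 `O=C(NNc1ccccc1F)c1ccccc1NS(=O)(=O)c1cnc(O)nc1O` differs from compound 3 by 2-fluorophenyl in place of 3-chlorophenyl on an amine nitrogen, the same change seen from compound 1 to compound 2. A step of similar size is expected here, a 2.7-fold higher number from compound 3 to compound 4 (0.43 log units; beyond the scatter), because the earlier step was an at least 2.3-fold higher number from compound 1 to compound 2 (0.37 log units; beyond the scatter). Compound 4 is therefore estimated at 15000 nM.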

Compound 4, half-maximal inhibitory concentration: 9570 nM
For compound 4 the middle estimate is 1.6-fold (0.20 log units) above the measured one, within the range that was stated.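

In this assay the second core gives a 1.7-fold higher number from compound 3 to compound 4 (0.24 log units; within the scatter) for 2-fluorophenyl in place of 3-chlorophenyl on an amine nitrogen, so on this core the change cannot be told apart from the ordinary spread of repeated measurements. Set beside the first core, the two steps cannot be said either to agree or to differ: the same change on two cores in this assay, an at least 2.3-fold higher number (0.37 log units; beyond the scatter) from compound 1 to compound 2 and a 1.7-fold higher number (0.24 log units; within the scatter) from compound 3 to compound 4; the limit leaves it open whether they differ. Compound 2 gives > 20000 nM, which is a limit of the assay and not a number, and the data show neither that the change carries over at the same size nor that it does not.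

Only these two groups appear on this amine nitrogen, so the compounds shown cannot separate the exchange of chlorine for fluorine from the shift in where the halogen sits on the ring. As far as these compounds go, how a plain phenyl, or a phenyl carrying an amine or a carboxylic acid, would fare on either core also stays open.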